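The compounds below may be only part of what the source reports. "The series", "measured", "known", "first", "only" and "open" are said of these compounds alone.

Measured so far in a functional assay on HT-29 cells (Homo sapiens) for cytotoxicity, read by MTT assay, with a stated time of 24 h; on this read-out higher numbers stand for weaker inhibition and lower numbers for stronger inhibition:
compound 1, `Cc1ccc2oc(-c3ccc(NC(=O)CN4CCN(CCCN(C)C)CC4)cc3)nc2c1`: 3890 nM
compound 2, `Cc1ccc2oc(-c3ccc(NC(=O)CN4CCN(CCCN(C)C)CC4)c(C)c3)nc2c1`: 12700 nM
compound 3, `CN(C)CCN1CCN(CC(=O)Nc2ccc(-c3nc4cc(Cl)ccc4o3)cc2)CC1`: 4470 nM

Among these three numbers compound 2 stands highest in this assay; compound 3 is nearest to it, with a lower number, and compound 1 lies furthest away, also lower. Within the data shown here, the only step between compounds that differ in one place is a 3.3-fold higher number from compound 1 to compound 2 (0.51 log units; beyond the scatter), a change on the aromatic ring of the shared core.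

Compound 4, `Cc1ccc2oc(-c3ccc(NC(=O)CN4CCN(CCN(C)C)CC4)c(C)c3)nc2c1`, has not yet been measured. It differs from compound 2 in one place: dimethylamino in place of (dimethylamino)methyl on a saturated chain carbon, two bonds along the chain from an amine nitrogen in a ring. Among the measured compounds shown here, no measured pair isolates this change. For the measured compounds named here, compound 1 and compound 3 differ from each other both in the length of this chain and in the substituent on the core, so no step between them can be read; in this assay compound 1 gives 3890 nM and compound 3 gives 4470 nM, numbers that lie within the scatter of each other. That comparison offers no sign that the chain length moves the number, so no step beyond the scatter is expected from compound 2 to compound 4, with a wide uncertainty. The estimate for compound 4 in this assay is 10000 nM, in a range of 4000 nM to 25000 nM. This estimate means an expected step of a 1.3-fold lower number from compound 2 to compound 4 (0.10 log units; within the scatter).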

Compound 4, half-maximal inhibitory concentration: 7240 nM
Beside the measured number, compound 4's estimate is 1.4-fold (0.14 log units) above it; the measured number falls inside the stated range.
By their numbers in this assay, from the lowest: compounds 1, 3, 4 and 2 (each within the scatter of the next, the first and the last beyond it).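

In this assay, among these compounds, the exchange of 3-(dimethylamino)propyl for 2-(dimethylamino)ethyl on the amine nitrogen in a ring gives a 1.8-fold lower number from compound 2 to compound 4 (0.24 log units; within the scatter), the first reading of this position in which nothing else changes. The earlier compounds shown here could not offer this, since compound 1 and compound 3 differ in both the chain and the substituent on the core, and no step between them can be read; here the chain alone differs, and in this single pair the shorter chain leaves the number within the scatter. Nothing measured here gives a reason for this result, so the data offer no explanation of it.

One pair on a single core cannot show whether the chain behaves alike on the core of compound 1 or on the chlorine-bearing core of compound 3, as neither has a partner differing only in the chain. Also open, as far as these compounds go, is what a longer chain such as 4-(dimethylamino)butyl, or a different end group such as diethylamino or morpholine, would do at this position.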